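This account rests on a few compounds, and the source may have more. Where it says the series, first, only, none or still open, it means among the compounds named here.

Measured in a functional assay on SGC-7901 cells (Homo sapiens) for cytotoxicity, read by MTT assay, with a stated time of 72 h; on this read-out higher numbers stand for weaker inhibition and lower numbers for stronger inhibition:
- compound 1 `CC(C)NC(=S)N/N=C1\CC(c2ccc(O)cc2)Oc2cc(O)ccc21`: 35200 nM
- compound 2 `Oc1ccc(C2C/C(=N\NC(=S)N3CCOCC3)c3ccc(O)cc3O2)cc1`: 52200 nM
- compound 3 `Oc1ccc(C2C/C(=N\NC(=S)N3CCCC3)c3ccc(O)cc3O2)cc1`: 37000 nM

Compound 3, at 37000 nM, cannot be told apart from the other two compounds, since all three values lie within the usual scatter of one another. The next compound, compound 4 `CCCN(CCC)C(=S)N/N=C1\CC(c2ccc(O)cc2)Oc2cc(O)ccc21`, has dipropylamino in place of pyrrolidin-1-yl on a thiocarbonyl carbon.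

For the measured compounds named here, three measured steps bear on this change, as each swaps one group at that same thiocarbonyl carbon: a 1.1-fold higher number from compound 1 to compound 3 (0.02 log units; within the scatter), a 1.4-fold lower number from compound 2 to compound 3 (0.15 log units; within the scatter) and a 1.5-fold higher number from compound 1 to compound 2 (0.17 log units; within the scatter). None goes beyond the scatter, so these three groups give no sign that this position shifts the reading in this assay. Going by the values given here, no measured compound carries dipropylamino, however, so this is a careful carry-over and not a direct comparison, and the range must stay wide.

No step beyond the scatter is expected, and the estimated move is a 1.1-fold lower number from compound 3 to compound 4 (0.05 log units; within the scatter). For compound 4 the expected value is 33000 nM, with an estimated range from 15000 nM to 65000 nM.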

Compound 4, half-maximal inhibitory concentration: 32200 nM
The estimate for compound 4 lay 1.0-fold (0.01 log units) above the measured number; low and high end bracket the measured number.
By their numbers in this assay, from the lowest: compounds 4, 1, 3 and 2 (each within the scatter of the next).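

Replacing the pyrrolidin-1-yl ring with the open-chain dipropylamino group, which has no ring and more heavy atoms, still leaves the reading in this assay within the scatter of all three earlier compounds: the steps are a 1.1-fold lower number from compound 3 to compound 4 (0.06 log units; within the scatter) and a 1.6-fold lower number from compound 2 to compound 4 (0.21 log units; within the scatter) and a 1.1-fold lower number from compound 1 to compound 4 (0.04 log units; within the scatter) for this new group. The earlier compounds shown here showed this only for isopropylamino and two ring groups, so an open-chain group with two propyl chains now joins them, and no change on this thiocarbonyl carbon has yet given a step beyond the scatter. Nothing available here explains why these four readings stay so close.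

Going by these compounds, whether a phenyl ring or a longer chain ending in an amine on this carbon would give a clear step remains open. So does the effect of any change made elsewhere on the shared core.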